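Removing one methyl group from compound 2

The compounds below may be only part of what the source reports. "The series", "measured", "known", "first", "only" and "open" are said of these compounds alone.

Measured in a functional assay on U-251 cells (Homo sapiens); on this read-out higher numbers stand for weaker inhibition of growth and lower numbers for stronger inhibition of growth:
Compound 1 `Oc1cc(-c2ccc(Cl)cc2)nc2ncccc12`: 39800 nM
Compound 2 `COc1cccc(-c2cc(O)c3c(C)cc(C)nc3n2)c1`: 170 nM
Compound 3 `COc1ccccc1-c1cc(O)c2ccc(C)nc2n1`: > 100000 nM

Compound 2 has the lower of the two true numbers, and its gap to compound 1 lies well beyond the usual scatter. The entry for compound 3 is a limit of the assay, not a number.

Compound 4 `COc1cccc(-c2cc(O)c3c(C)ccnc3n2)c1` differs from compound 2 in one place: hydrogen in place of methyl on an aromatic carbon. Hydrogen stands in place of methyl on an aromatic carbon, next to the ring nitrogen.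

Among the measured compounds shown here, no measured pair shows this change alone. Compound 1 also lacks this methyl and gives 39800 nM, but it differs from compound 2 in other places too, so that gap cannot be assigned to the methyl alone. A moderate weakening in this assay is therefore expected, far smaller than that gap, with a wide margin of doubt. The estimated change is a 4.7-fold higher number from compound 2 to compound 4 (0.67 log units; beyond the scatter). For compound 4 the expected value is 800 nM, with an estimated range of 150 nM to 6000 nM.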

Compound 4, concentration for 50% growth inhibition: 58.9 nM
Compound 4: the middle estimate sits 14-fold (1.13 log units) above what was measured, and the stated range ends above it.
By their numbers in this assay, from the lowest: compound 4; then compound 2; then compound 1. At a limit, above all of these: compound 3.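

With hydrogen in place of the methyl group next to the ring nitrogen, growth inhibition in this assay does not weaken but gets modestly stronger: a 2.9-fold lower number from compound 2 to compound 4 (0.46 log units; beyond the scatter). Among the compounds shown here, this is the first direct reading of this change, as no earlier pair differed in this one place alone, and it shows that this methyl group is not needed for activity on the shared core. The values shown offer no explanation for the gain.

As far as these compounds go, it remains open how an amine, a carboxylic acid or a longer chain at this position would compare with hydrogen and methyl. Also open, from the compounds shown here alone, is whether removing the other methyl group, which compound 2 and compound 4 both keep, would change the number in the same direction.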